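The compounds below may be only part of what the source reports. "The series", "measured", "known", "first", "only" and "open" are said of these compounds alone.

Measured compounds:
- Compound 1, `CC(=O)OCC(CCn1cc(C#Cc2cc(F)cc(F)c2)c(=O)n(C(=O)c2ccccc2)c1=O)COC(C)=O`: 28900 nM
- Compound 2, `CC(=O)OCC(CCn1cc(C#Cc2ccc(Br)cc2)c(=O)n(C(=O)c2ccccc2)c1=O)COC(C)=O`: 28900 nM
- Compound 3, `CCCCCc1ccc(C#Cc2cn(CCC(COC(C)=O)COC(C)=O)c(=O)n(C(=O)c3ccccc3)c2=O)cc1`: 100 nM

In a functional assay on MCF7 cells (Homo sapiens) for antiproliferative activity, read by MTT assay, with a stated time of 72 h (a lower number here means a stronger inhibitor, a higher number a weaker inhibitor), compound 3 gives the lowest of the three numbers, with 100 nM; both other compounds lie far from it, as the steps of a 290-fold lower number from compound 1 to compound 3 (2.46 log units; beyond the scatter) and a 290-fold lower number from compound 2 to compound 3 (2.46 log units; beyond the scatter) show, while no change at the digits printed from compound 1 to compound 2 (within the scatter) shows the two aryl-halide compounds sitting together.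

Compound 4, `CC(=O)OCC(CCn1cc(C#CCc2ccccc2)c(=O)n(C(=O)c2ccccc2)c1=O)COC(C)=O`, is the next compound. It differs from compound 3 in one place: benzyl in place of 4-pentylphenyl on a triple-bonded carbon. Going by the values given here, the step that bears most directly on this change is a 290-fold lower number from compound 2 to compound 3 (2.46 log units; beyond the scatter), where the pentyl chain on the aromatic carbon was the only difference and the number fell sharply. Compound 4 gives up that pentyl chain and also moves the aromatic ring away from the triple-bonded carbon by one carbon. Among the compounds with values here, no measured pair tests the benzyl itself, so the size of the step is uncertain, but with the pentyl chain gone a return toward the numbers of compound 1 and compound 2 is expected.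

Compound 4 is therefore expected to give about 15000 nM in this assay, within a range of 3000 nM to 50000 nM, which means an expected step of a 150-fold higher number from compound 3 to compound 4 (2.18 log units; beyond the scatter).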

Compound 4, half-maximal inhibitory concentration: 26800 nM
Estimate against measurement, compound 4: 1.8-fold (0.25 log units) below, and the stated range covers the measured number.
By their numbers in this assay, from the lowest: compound 3; then compounds 4, 1 and 2 (each within the scatter of the next).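

In this assay, the benzyl group falls in with the two halogen-bearing aryl groups and not with the 4-pentylphenyl group, as shown by the steps (a 1.1-fold lower number from compound 2 to compound 4 (0.03 log units; within the scatter)) and (a 1.1-fold lower number from compound 1 to compound 4 (0.03 log units; within the scatter)), whereas replacing 4-pentylphenyl with benzyl gives a large step (a 270-fold higher number from compound 3 to compound 4 (2.43 log units; beyond the scatter)). On this triple-bonded carbon, therefore, benzyl, 4-bromophenyl and 3,5-difluorophenyl all sit at one level, although benzyl places its ring one carbon further away, and among the four compounds only the 4-pentylphenyl group stands apart. Nothing measured here explains why that group differs from the other three.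

The compounds shown leave open how much of the pentyl chain is needed, which a butyl or hexyl chain on the same ring would test, and whether a pentyl chain on the ring of the benzyl group would restore the low number of compound 3. They also leave open whether an amine or a carboxylic acid at the end of such a chain would keep that number.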